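A few compounds are considered here, and "the series" means these few. Any claim that something is new, unique, unknown or untested is made for them only; others in the source may bear on it.

In a toxicity assay on NIH3T3 cells (Mus musculus) for cytotoxicity, read by resazurin assay (a higher number here means that more compound is needed for the effect, a lower number that less compound is needed), none of the three measured compounds gives an exact number. Compound 1 `Nc1cc(-c2ccccc2)ccc1Cn1cncc1CNc1ccc(Cl)c(-c2ccccc2)c1` gives > 1000 nM, which is a limit. Compound 2 `COc1ccc(NCc2cncn2Cc2ccc(-c3ccccc3)cc2N)cc1-c1ccccc1` gives > 1000 nM, also a limit. Compound 3 `COC(=O)c1ccc(NCc2cncn2Cc2cccc([N+](=O)[O-])c2)cc1-c1ccccc1` gives > 10000 nM, again a limit, so its true value is not known and it can be placed only by that limit.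

Compound 4 `COC(=O)c1ccc(NCc2cncn2Cc2cccc(C)c2)cc1-c1ccccc1` has not yet been measured. It keeps the rest of compound 3 and changes one group: methyl in place of nitro on an aromatic carbon. In words, this is methyl in place of nitro on an aromatic carbon, turning 3-nitrobenzyl into 3-methylbenzyl.

For the measured compounds named here, only one measured step exists to compare with, a step that the two limits leave unreadable from compound 1 to compound 2. That step is a different change, methoxy in place of chloro on an aromatic carbon, and its size cannot be read, so it offers neither a size nor a direction to carry over. The expectation therefore rests on compound 3 at > 10000 nM, and compound 4 may well return only a limit too. The expected step that the limit leaves unreadable from compound 3 to compound 4 is no larger than the usual scatter, with no direction predicted. Compound 4 is estimated at 12000 nM, with an expected range of 4000 nM to 30000 nM.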

Compound 4, half-maximal effective concentration: > 10000 nM
Compound 4 ended at the assay's limit; the forecaster's own chance of this, stated with the estimate: 80%; the middle value does not contradict the limit.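

In this assay compound 4 gives > 10000 nM, which is a limit. Compound 3 gives > 10000 nM, also a limit, so no step can be read between compound 3 and compound 4. The compounds shown leave open where the true values of these compounds lie, and whether methyl in place of nitro shifts the value at all.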